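Furan-3-yl for Thiophen-2-yl on Two Nucleoside Cores

The source may report more compounds than this note shows. Statements on the series, on what has been measured and on what is new or still open speak of the compounds shown alone.

Compound 1 `COc1ncnc2c1c(-c1ccoc1)cn2[C@@H]1O[C@H](CO)[C@@H](O)[C@H]1O`: 28800 nM
Compound 2 `COc1ncnc2c1c(-c1cccs1)cn2[C@@H]1O[C@H](CO)[C@@H](O)[C@H]1O`: 62800 nM
Compound 3 `Nc1nc2c(c(-c3cccs3)cn2[C@@H]2O[C@H](CO)[C@@H](O)[C@H]2O)c(=O)[nH]1`: > 100000 nM

In an ADME assay on BJ cells (Homo sapiens), read by MTT assay, with a stated time of 72 h (on this read-out higher numbers stand for weaker inhibition and lower numbers for stronger inhibition), compound 2 gives 62800 nM and compound 1 gives 28800 nM. The step between them, a 2.2-fold lower number from compound 2 to compound 1 (0.34 log units; beyond the scatter), comes from one change: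

furan-3-yl in place of thiophen-2-yl on an aromatic carbon

In this assay compound 3 gives > 100000 nM, which is a limit of the assay and not a number. Compound 3 stands at that limit: the limit of > 100000 nM in this assay, at which 1 of the 3 values shown sits. How the core of compound 3 differs from the core of compound 2 is not broken down here.

Compound 4 `Nc1nc2c(c(-c3ccoc3)cn2[C@@H]2O[C@H](CO)[C@@H](O)[C@H]2O)c(=O)[nH]1` differs from compound 3 by the same change:

furan-3-yl in place of thiophen-2-yl on an aromatic carbon

The step to compound 4 is expected to be an at least 1.2-fold lower number from compound 3 to compound 4 (0.09 log units; that floor lies within the scatter), resting on the earlier step of a 2.2-fold lower number from compound 2 to compound 1 (0.34 log units; beyond the scatter). Because the starting value of compound 3 in this assay is only a limit, > 100000 nM, the expected number itself is loosely fixed. Compound 4 is estimated at 80000 nM, between 35000 nM and 250000 nM, with a fair chance that only a limit is reported again.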

Compound 4, half-maximal inhibitory concentration: 21500 nM
Beside the measured number, compound 4's estimate is 3.7-fold (0.57 log units) above it; the whole stated range lies above it.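

In this assay, furan-3-yl in place of thiophen-2-yl also gives a lower number on the second core, an at least 4.6-fold lower number from compound 3 to compound 4 (0.66 log units; beyond the scatter). The direction of the step therefore carries over between the two cores shown, but its full size on the second core is not fixed, and a larger step there cannot be claimed: the same change on two cores in this assay, a 2.2-fold lower number (0.34 log units; beyond the scatter) from compound 2 to compound 1 and an at least 4.6-fold lower number (0.66 log units; beyond the scatter) from compound 3 to compound 4; the limit leaves it open whether they differ. Compound 3 rests on a limit of the assay and not on a number: the limit of > 100000 nM in this assay, at which 1 of the 4 values shown sits.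

Going by these compounds alone, with only two pairs, it remains open whether the direction would hold on further cores. Going by these compounds, it is also open how other groups at this place, such as a phenyl ring, an amine or a carboxylic acid, would compare with furan-3-yl.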